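A few compounds are considered here, and "the series" means these few. Any claim that something is new, unique, unknown or untested is made for them only; others in the source may bear on it.

Measured compounds:
compound 1 `O=C(CSc1nc(Nc2ccccc2)c2ccccc2n1)Nc1ccccc1Cl` — 24800 nM
compound 2 `O=C(CSc1nc(Nc2ccccc2)c2ccccc2n1)Nc1ccc(Cl)cc1` — 40400 nM
compound 3 `C=CC(=O)Nc1cccc(NC(=O)CSc2nc(Nc3cccc(F)c3)c3ccccc3n2)c1` — 6250 nM

In a functional assay on MGC-803 cells (Homo sapiens) for inhibition, read by MTT assay, with a stated time of 72 h (a higher number here means a weaker inhibitor, a lower number a stronger inhibitor), compound 3 gives the lowest number of the three, and its gaps to compound 1 and to compound 2 both lie beyond the usual scatter, so it is the strongest inhibitor among the measured compounds.

Compound 4 `C=CC(=O)Nc1cccc(NC(=O)CSc2nc(Nc3ccc(CC)cc3)c3ccccc3n2)c1` has not yet been measured. It differs from compound 3 in one place: 4-ethylphenyl in place of 3-fluorophenyl on a nitrogen on an aromatic ring.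

The only measured step among these compounds, a 1.6-fold higher number from compound 1 to compound 2 (0.21 log units; within the scatter), swaps substituents on an amide-type nitrogen, a different position from the one changed here, and it stayed within the scatter. Within the data shown here, no measured step touches the nitrogen on the aromatic ring, so there is no direct guide for the move from 3-fluorophenyl to 4-ethylphenyl at that place. Among the measured compounds shown here, the one available comparison suggests that swapping one substituted phenyl for another can leave the number roughly where it was.

On that basis no step beyond the scatter is expected, and the estimated step is a 1.3-fold higher number from compound 3 to compound 4 (0.11 log units; within the scatter). Compound 4 is therefore expected to give about 8000 nM, within a range from 2500 nM to 25000 nM.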

Compound 4, half-maximal inhibitory concentration: 8010 nM
Estimate against measurement, compound 4: 1.0-fold (0.00 log units) below; the range from low to high includes it.
By their numbers in this assay, from the lowest: compounds 3 and 4 (each within the scatter of the next); then compounds 1 and 2 (each within the scatter of the next).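

Among these compounds, at the nitrogen on an aromatic ring, the earlier compounds gave no reading, and this assay now supplies the first one: 4-ethylphenyl in place of 3-fluorophenyl gives a 1.3-fold higher number from compound 3 to compound 4 (0.11 log units; within the scatter). So the number stays put even though the fluorine is gone, an ethyl group has arrived, and the group on the ring sits at a different printed position, which means this place in the series can take at least these two substituted phenyl groups with no change that stands out from the scatter. Nothing available explains why these two numbers stay so close.

The swap changes the kind of substituent and its position together, so the two changes cannot be told apart here, and a small effect from one could be hidden by an opposite effect from the other. Also open, going by these compounds, is whether this place stays as undemanding with a group of a different kind on the phenyl ring, such as an amine, a carboxylic acid or a chain longer than ethyl.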